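Dimethoxyphenyl amide on the flavonol core

The compounds below may be only part of what the source reports. "The series", "measured", "known", "first", "only" and "open" are said of these compounds alone.

Three amides sharing one core have been measured in a functional assay on HCC1937 cells (Homo sapiens) for antiproliferative activity, read by CCK-8 assay, with a stated time of 72 h; a higher number here means a weaker inhibitor, a lower number a stronger inhibitor. Compound 1 `O=C(Nc1cccc(-c2oc3cc(-c4ccc(F)cc4)ccc3c(=O)c2O)c1)c1ccc(F)cc1` gives 14200 nM. Compound 2 `O=C(Nc1cccc(-c2oc3cc(-c4ccc(F)cc4)ccc3c(=O)c2O)c1)c1ccc(C(F)(F)F)cc1` gives 7350 nM, and compound 3 `O=C(Nc1cccc(-c2oc3cc(-c4ccc(F)cc4)ccc3c(=O)c2O)c1)c1cccc(F)c1` gives 6590 nM. Among these three, compound 3 holds the lowest number; one of the two steps that lead to it is a 1.1-fold lower number from compound 2 to compound 3 (0.05 log units; within the scatter), which is within the scatter, while the other is a 2.2-fold lower number from compound 1 to compound 3 (0.33 log units; beyond the scatter), a modest step. The step of a 1.9-fold lower number from compound 1 to compound 2 (0.29 log units; within the scatter) is also within the scatter, so changes on the aryl amide have so far moved this assay only a little.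

Compound 4 `COc1cc(OC)cc(C(=O)Nc2cccc(-c3oc4cc(-c5ccc(F)cc5)ccc4c(=O)c3O)c2)c1` differs from compound 3 in one place: 3,5-dimethoxyphenyl in place of 3-fluorophenyl on a carbonyl carbon. Going by the values given here, the steps that bear on this are those in which the aryl amide was altered, that is a 2.2-fold lower number from compound 1 to compound 3 (0.33 log units; beyond the scatter) and a 1.1-fold lower number from compound 2 to compound 3 (0.05 log units; within the scatter), both small. Among the compounds with values here, no measured pair shows a methoxy group, so the effect of two of them on the ring is unknown here. On this basis the step of a 1.0-fold lower number from compound 3 to compound 4 (0.01 log units; within the scatter) is expected to stay within the scatter, with no clear direction. Compound 4 is therefore estimated at 6500 nM, with a range from 2500 nM to 17000 nM.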

Compound 4, half-maximal inhibitory concentration: 6250 nM
For compound 4 the middle estimate is 1.0-fold (0.02 log units) above the measured one, and the stated range covers the measured number.
By their numbers in this assay, from the lowest: compounds 4, 3, 2 and 1 (each within the scatter of the next, the first and the last beyond it).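

In this assay, going by these compounds alone, the 3,5-dimethoxyphenyl amide shows that two methoxy groups can replace the single fluorine of compound 3 with no readable shift (a 1.1-fold lower number from compound 3 to compound 4 (0.02 log units; within the scatter)), even though the entering aryl group carries hydrogen-bond acceptors and the 3-fluorophenyl carries none. Within the data shown here, the comparison with the 4-(trifluoromethyl)phenyl amide likewise stays within the scatter (a 1.2-fold lower number from compound 2 to compound 4 (0.07 log units; within the scatter)), while the step from the 4-fluorophenyl amide is modest (a 2.3-fold lower number from compound 1 to compound 4 (0.36 log units; beyond the scatter)) and close in size to the one already seen for compound 3 (a 2.2-fold lower number from compound 1 to compound 3 (0.33 log units; beyond the scatter)), so compound 1 stands apart from compound 3 and compound 4, but not from compound 2. No measurement on these compounds explains why such different aryl groups on this carbonyl carbon give such similar numbers.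

All four compounds carry an aryl group on the amide carbonyl, so the compounds shown leave open whether this position needs an aromatic ring at all. Going by these compounds, what an amine, a carboxylic acid or a longer alkyl chain would do in place of that ring also remains open.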